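A few compounds are considered here, and "the series" means these few. Any claim that something is new, unique, unknown or untested is made for them only; others in the source may bear on it.

In an ADME assay on Jurkat cells (Homo sapiens) for cytotoxicity, read by trypan blue exclusion, with a stated time of 24 h (a lower number here means a stronger inhibitor, a higher number a weaker inhibitor), compound 1 (`N#C[Se]Cc1cccc([N+](=O)[O-])c1`) gives 12200 nM. Compound 2 (`Cc1ccc(C[Se]C#N)cc1`) gives 14400 nM. Going by the values given here, these two numbers lie within the scatter of each other, so compound 1 stands level with the only other measured compound and no ranking can be drawn.

Compound 3 (`N#C[Se]Cc1cccc(C#N)c1`) keeps the core of compound 1, with cyano in place of nitro on an aromatic carbon. Among the compounds with values here, no pair of measured compounds differs in one place only, so the data give no direct size for this change. No shift beyond the scatter is expected in this assay, in either direction, and the starting point is compound 1 at 12200 nM. The estimated step of a 1.1-fold higher number from compound 1 to compound 3 (0.03 log units; within the scatter) is expected to stay within the scatter. For compound 3 the estimate is 13000 nM, with an expected range of 6500 nM to 26000 nM.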

Compound 3, half-maximal inhibitory concentration: 8710 nM
Estimate against measurement, compound 3: 1.5-fold (0.17 log units) above; the measured number falls inside the stated range.
By their numbers in this assay, from the lowest: compounds 3, 1 and 2 (each within the scatter of the next).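

In this assay, going by these compounds alone, cyano in place of nitro on an aromatic carbon, meta to a group of 4 heavy atoms, gives the first one-place step (a 1.4-fold lower number from compound 1 to compound 3 (0.15 log units; within the scatter)), and this step stays within the scatter. At this position, then, the exchange leaves the cytotoxicity read-out without a change that can be read, even though the two groups differ in heavy atoms, bond type and hydrogen-bond acceptors. No measured property of either group bears on this result.

As far as these compounds go, whether a different kind of group at this position, such as an amine or a carboxylic acid, would shift the number beyond the scatter remains open. Also open, from the compounds shown here alone, is what a change to the shared core would do, for example a longer chain in place of the single carbon link.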